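This account rests on a few compounds, and the source may have more. Where it says the series, first, only, none or still open, it means among the compounds named here.

Measured compounds:
Compound 1, `COc1ccc(NC[C@H](O)COc2ccc(N3C[C@H](CNC(C)=O)OC3=O)cc2F)cc1`, 56000 nM
Compound 2, `CC(=O)NC[C@H]1CN(c2ccc(OC[C@@H](O)CNc3ccccc3)c(F)c2)C(=O)O1`, 124000 nM
Compound 3, `CC(=O)NC[C@H]1CN(c2ccc(OC[C@@H]3CN(c4ccccc4)C(=O)O3)c(F)c2)C(=O)O1`, 14000 nM

In a physicochemical assay for solubility, read by HPLC (a lower number here means a less soluble compound, a higher number a more soluble compound), compound 2 gives 124000 nM, compound 1 gives 56000 nM and compound 3 gives 14000 nM. Compound 1 differs from compound 2 by methoxy in place of hydrogen on an aromatic carbon, and this change produced a 2.2-fold lower number from compound 2 to compound 1 (0.35 log units; beyond the scatter). Compound 3 has the lowest number of the three; the difference between its core and the core of compound 2 is not broken down here.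

Compound 4, `COc1ccc(N2C[C@@H](COc3ccc(N4C[C@H](CNC(C)=O)OC4=O)cc3F)OC2=O)cc1`, has not yet been measured in this assay. It differs from compound 3 by methoxy in place of hydrogen on an aromatic carbon. This is the same change as the one from compound 2 to compound 1, at the same kind of place, and it occurs twice among these compounds. For compound 4 a step of similar size is expected, namely a 2.2-fold lower number from compound 3 to compound 4 (0.34 log units; beyond the scatter). For the measured compounds named here, that expectation rests on the measured step of a 2.2-fold lower number from compound 2 to compound 1 (0.35 log units; beyond the scatter), with only one such pair to lean on. Compound 4 is therefore estimated at 6400 nM, expected to fall between 2500 nM and 16000 nM.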

Compound 4, solubility: 132000 nM
The estimate for compound 4 lay 21-fold (1.31 log units) below the measured number; measured number above the stated range.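

In this assay, the change from phenyl to 4-methoxyphenyl gave a 9.4-fold higher number from compound 3 to compound 4 (0.97 log units; beyond the scatter) while the same change on the core of compound 2 gave a 2.2-fold lower number from compound 2 to compound 1 (0.35 log units; beyond the scatter) and so the two steps run in opposite directions, and the step measured on one core did not carry over to the other. With a single pair on each core, this shows only that the direction of the change differed between these two cores; it gives no rule for any further core. Nothing available bears on why the two steps part, so the reversal stays unexplained.

Left open is whether another group at the same place, such as an amine or a carboxylic acid, would follow the step seen on the core of compound 3 or the one seen on the core of compound 2. The compounds shown also leave open how a longer chain, such as ethoxy in place of methoxy, would behave on either core.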